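The source may report more compounds than this note shows. Statements on the series, on what has been measured and on what is new or still open speak of the compounds shown alone.

In a functional assay on the whole organism for inhibition, with Rattus norvegicus as the target, with a stated time of 1 h (a higher number here means that more compound is needed for the effect, a lower number that less compound is needed), three compounds have been measured:

Compound 1 `CC1(C)OC(/C=C/c2cccnc2)=CC1=O`: 9 mg/kg
Compound 2 `CC1(C)OC(/C=C/c2ccccc2)=CC1=O`: 17 mg/kg
Compound 3 `CC1(C)OC(/C=C/c2ccc(C#N)cc2)=CC1=O`: 12 mg/kg

Compound 3, at 12 mg/kg, lies within the scatter of both compound 1 and compound 2, so these three values cannot be ranked. Compound 4 `CC1(C)OC(/C=C/c2ccc(Br)cc2)=CC1=O` has bromo in place of cyano on an aromatic carbon. Among the compounds with values here, the one measured step that bears on this change is a 1.4-fold lower number from compound 2 to compound 3 (0.15 log units; within the scatter), where cyano replaces hydrogen on an aromatic carbon. Within the data shown here, no bromo compound has been measured. Among the measured compounds shown here, with only that small step as a guide, no change beyond the scatter is expected in this assay. The expected step is a 1.1-fold higher number from compound 3 to compound 4 (0.03 log units; within the scatter). For compound 4 the estimated value is 13 mg/kg, with an expected range of 6 mg/kg to 28 mg/kg.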

Compound 4, dose for half-maximal effect: 18 mg/kg
Compound 4: middle estimate off by 1.4-fold (0.14 log units), on the low side; the measured number falls inside the stated range.
By their numbers in this assay, from the lowest: compounds 1, 3, 2 and 4 (each within the scatter of the next).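

Exchanging cyano for bromo on this aromatic carbon, para to a large group, gives a 1.5-fold higher number from compound 3 to compound 4 (0.18 log units; within the scatter) and placing bromo there in place of hydrogen gives a 1.1-fold higher number from compound 2 to compound 4 (0.02 log units; within the scatter) in this assay. Hydrogen, cyano and bromo at this position therefore cannot be told apart in this assay, although cyano carries a triple bond and a hydrogen-bond acceptor and bromo carries neither. No measurement at hand explains these small steps. From the compounds shown here alone, whether an amine, a carboxylic acid or a longer chain at this position would give a step beyond the scatter remains open.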